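The compounds below may be only part of what the source reports. "The series", "measured", "known", "first", "only" and "open" are said of these compounds alone.

Measured so far:

- compound 1, `COc1ccc(-c2cnc(NC(=O)c3ccc(Br)cc3)n2C)cc1`, in a toxicity assay on THP-1 cells (Homo sapiens) for inhibition; a lower number here means that less compound is tolerated, a higher number that more compound is tolerated: > 100000 nM, a limit of the assay and not a number
- compound 2, `Cn1c(-c2ccccc2Br)cnc1NC(=O)c1ccc(F)cc1`, in this assay: > 100000 nM, again a limit of the assay
- compound 3, `COc1ccc(C(=O)Nc2ncc(-c3ccc(OC)cc3)n2C)cc1`, in this assay: > 100000 nM, also a limit of the assay

Compound 3 arises from compound 1 through (methoxy in place of bromo on an aromatic carbon), and the step that the two limits leave unreadable from compound 1 to compound 3 cannot be read in size, because of the limit of > 100000 nM in this assay, at which 3 of the 3 values shown sit. How the core of compound 2 differs from that of compound 1 is not broken down here.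

Compound 4, `COc1ccccc1-c1cnc(NC(=O)c2ccc(F)cc2)n1C`, is still to be measured in this assay. It arises from compound 2 through (methoxy in place of bromo on an aromatic carbon). This is the same kind of change as that from compound 1 to compound 3, but not the same change: there the methoxy stands para to a large group, here ortho to a large group.

Since both compound 1 and compound 3 sit at the limit, the step for compound 4 is expected to be a number no higher from compound 2 to compound 4 (the limit leaves the size open), resting on the unreadable step that the two limits leave unreadable from compound 1 to compound 3. Compound 4 is therefore estimated at 100000 nM, between 30000 nM and 300000 nM, most likely again reported only as a limit.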

Compound 4, half-maximal cytotoxic concentration: > 100000 nM
Compound 4: only a limit was reported (the forecaster's own chance of this, stated with the estimate: 85%); the middle value lies on the limit itself.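

Compound 2 and compound 4 are both reported in this assay only as limits of the assay and not as numbers, so no step can be read between them, because the result gives no size to compare: the limit of > 100000 nM in this assay, at which 4 of the 4 values shown sit.

The compounds shown leave open whether methoxy in place of bromo changes the read-out in this assay at all.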